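The compounds below may be only part of what the source reports. "The series", "measured", "known", "first", "only" and "open" are said of these compounds alone.

Measured so far:
compound 1, `Cc1ccc(O)c(C(O)(C(F)(F)F)C(F)(F)F)c1`, 454000 nM in an assay on isolated protein for inhibition of tyrosine-protein phosphatase non-receptor type 13 (Homo sapiens), read by spectrophotometry; a higher number here means a weaker inhibitor, a lower number a stronger inhibitor
compound 2, `CC(C)c1ccc(NC(=O)COc2ccc3cc(C(O)(C(F)(F)F)C(F)(F)F)c(O)cc3c2)cc1`, 6500 nM in this assay
compound 3, `O=C(COc1ccc2cc(C(O)(C(F)(F)F)C(F)(F)F)c(O)cc2c1)N(c1ccccc1)c1ccccc1`, 12400 nM in this assay

Of these three numbers, compound 1 has the highest, which makes it the weakest inhibitor of the three; both compound 2 and compound 3 lie well beyond the scatter of repeated measurements from it. Compound 2 and compound 3 are considerably larger molecules than compound 1, which is a single ring bearing a hydroxy group, the hexafluoro carbinol and a methyl group.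

Compound 4, `Oc1ccc(-c2ccccc2)cc1C(O)(C(F)(F)F)C(F)(F)F`, is the next step from compound 1: phenyl in place of methyl on an aromatic carbon. Within the data shown here, no directly comparable step has been measured, so the size of the change in this assay can only be estimated. The only hint is that the much larger compound 2 and compound 3 give far lower numbers than compound 1, and the extra phenyl ring moves compound 4 some way toward that size. The expected step in this assay is a 4.5-fold lower number from compound 1 to compound 4 (0.66 log units; beyond the scatter), a moderate lowering of the number that should exceed the scatter without reaching the values of compound 2 or compound 3. Compound 4 is estimated at 100000 nM, with a likely range from 25000 nM to 400000 nM.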

Compound 4, half-maximal inhibitory concentration: > 500000 nM
Compound 4: a limit, no number (the forecaster's own chance of this, stated with the estimate: 15%); middle value at least 5.0-fold (0.69 log units) away from the limit.
By their numbers in this assay, from the lowest: compounds 2 and 3 (each within the scatter of the next); then compound 1. At a limit, above all of these: compound 4.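

In this assay compound 4 gives > 500000 nM and this is a limit of the assay, not a number. Phenyl in place of methyl on this aromatic carbon, para to a hydroxy group, gives an at least 1.1-fold higher number from compound 1 to compound 4 (0.04 log units; that floor lies within the scatter) and so brings no lowering of the number, while the floor of that step is too small to establish a real rise. The true size of the step cannot be read because the measurement of compound 4 ends at a limit: the limit of > 500000 nM in this assay, at which 1 of the 4 values shown sits.

With only methyl and phenyl shown at this carbon, it remains open whether a different group here, such as an amine, a carboxylic acid or a phenyl held on a longer chain, would lower the number. As far as these compounds go, compound 2 and compound 3 differ from compound 1 in more than one place, so it also remains open which of their differences goes with their lower numbers.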